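Trimming the Amide Tail: Propyl Replaces Phenyl

This account rests on a few compounds, and the source may have more. Where it says the series, first, only, none or still open, it means among the compounds named here.

Compound 2 `O=C(Nc1cccc(-c2oc3cc(-c4ccc(F)cc4)ccc3c(=O)c2O)c1)c1ccc(-c2ccccc2)cc1` carries a 4-phenylphenyl group on the amide carbonyl carbon of the shared core. In a functional assay on A549 cells (Homo sapiens) for antiproliferative activity, read by CCK-8 assay, with a stated time of 72 h (a higher number here means a weaker inhibitor, a lower number a stronger inhibitor), compound 2 reaches only the assay limit, > 100000 nM, so no number is known for it. Compound 1 `Cc1ccccc1C(=O)Nc1cccc(-c2oc3cc(-c4ccc(F)cc4)ccc3c(=O)c2O)c1`, with 2-methylphenyl in that position, gives 17600 nM. Within the data shown here, the single measured step, an at least 5.6-fold higher number from compound 1 to compound 2 (0.75 log units; beyond the scatter), rests on the limit of > 100000 nM in this assay, at which 1 of the 2 values shown sits, and shows the biphenyl tail as the weaker of the two. Compound 3 `CCCc1ccc(C(=O)Nc2cccc(-c3oc4cc(-c5ccc(F)cc5)ccc4c(=O)c3O)c2)cc1` differs from compound 2 by propyl in place of phenyl on an aromatic carbon: 4-phenylphenyl becomes 4-propylphenyl, a chain in place of the second ring. Among the measured compounds shown here, no measured step covers this exact change, so the expectation leans on the one measured direction alone. Compound 3 is therefore expected to come back off the limit, estimated at 40000 nM within 10000 nM to 150000 nM. The step of an at least 2.5-fold lower number from compound 2 to compound 3 (0.39 log units; beyond the scatter) is expected to be a modest fall in number. Compound 3 may still stop at the limit.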

Compound 3, half-maximal inhibitory concentration: 47600 nM
Estimate against measurement, compound 3: 1.2-fold (0.08 log units) below; low and high end bracket the measured number.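

In this assay, replacing the outer phenyl with propyl gives a tail that returns a measurable number, so this position does not reject every group at the end of the aromatic ring on the amide carbonyl carbon. The change is an at least 2.1-fold lower number from compound 2 to compound 3 (0.32 log units; beyond the scatter). The value of compound 2 is a limit, so the size of this step is only a bound: the limit of > 100000 nM in this assay, at which 1 of the 3 values shown sits.

The chain does not restore the activity of the small tail, however, as swapping 2-methylphenyl for 4-propylphenyl gives a 2.7-fold higher number from compound 1 to compound 3 (0.43 log units; beyond the scatter).

Those two tails differ both in the group and in where it sits on the ring, and the compounds shown do not separate these two changes. A 4-methylphenyl tail, a longer chain such as hexyl, or an amine at the end of the propyl chain would each probe this position further.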